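The compounds below may be only part of what the source reports. "The series", "measured", "known", "first", "only" and "open" are said of these compounds alone.

Measured compounds: compound 1 `O=C(Nc1cc(C(F)(F)F)cc(C(F)(F)F)c1)C1CCc2ccccc2N1C(=O)c1ccccc1Cl` gives 2080 nM in a functional assay on NCI-H23 cells (Homo sapiens) for cytotoxicity, read by sulforhodamine B assay, with a stated time of 72 h; on this read-out higher numbers stand for weaker inhibition of growth and lower numbers for stronger inhibition of growth. Compound 2 `O=C(Nc1ccccc1C(F)(F)F)C1CCc2ccccc2N1` gives 56800 nM. Compound 3 `CCCC(=O)N1c2ccccc2CCC1C(=O)Nc1ccccc1C(F)(F)F` reaches only a limit of the assay, > 70000 nM.

Of the two numbers shown, compound 1 stands lowest, and its gap to compound 2 lies beyond the scatter. The change to compound 4 `CCCCCCCCC(=O)N1c2ccccc2CCC1C(=O)Nc1cc(C(F)(F)F)cc(C(F)(F)F)c1` is octyl in place of 2-chlorophenyl on a carbonyl carbon. Among the compounds with values here, the one measured step, an at least 1.2-fold higher number from compound 2 to compound 3 (0.09 log units; that floor lies within the scatter), also places an alkylcarbonyl on that ring nitrogen and ends at the limit of > 70000 nM in this assay, at which 1 of the 3 values shown sits, yet it starts from a free nitrogen rather than exchanging an aryl for an alkyl, so it bears on the present step only loosely. A move toward weaker growth inhibition is nonetheless expected, a 4.8-fold higher number from compound 1 to compound 4 (0.68 log units; beyond the scatter). Compound 4 is therefore estimated at 10000 nM, with a range from 2500 nM to 40000 nM.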

Compound 4, concentration for 50% growth inhibition: 3230 nM
For compound 4 the middle estimate is 3.1-fold (0.49 log units) above the measured one; low and high end bracket the measured number.
By their numbers in this assay, from the lowest: compounds 1 and 4 (each within the scatter of the next); then compound 2. At a limit, above all of these: compound 3.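

In this assay, an octyl chain on this carbonyl carbon reads the same as a 2-chlorophenyl group, within the usual scatter: a 1.6-fold higher number from compound 1 to compound 4 (0.19 log units; within the scatter). For this pair, then, the aromatic ring and its chlorine can be exchanged for an open carbon chain without a clear change in growth inhibition. Nothing measured here explains why the two groups read alike. As far as these compounds go, it remains open whether a much shorter chain, such as ethyl, would read the same on the core of compound 1. The same holds for an octyl chain ending in an amine or a carboxylic acid.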